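Bringing the oxygen ring back to a short-lived compound

A few compounds are considered here, and "the series" means these few. Any claim that something is new, unique, unknown or untested is made for them only; others in the source may bear on it.

In an ADME assay on microsomes from liver (Rattus norvegicus) for metabolic stability (on this read-out higher numbers stand for a longer-lived compound and lower numbers for a shorter-lived compound), compound 3 `CC(C)[C@H](C[C@H]1SC(=O)NC1=O)c1ccc(-c2ccc3cccc(F)c3c2)[nH]c1=O` gives 0.143 h, the lowest of the three measured numbers. Compound 1 `CC(C)[C@H](C[C@H]1OC(=O)NC1=O)c1ccc(-c2ccc3cccc(F)c3c2)[nH]c1=O` gives 0.95 h, and compound 2 `CC(C)[C@@H](c1ccc(-c2ccc3cccc(F)c3c2)[nH]c1=O)[C@H]1OC(=O)NC1=O` gives 1.93 h. Compound 4 `CC(C)[C@H](C[C@@H]1OC(=O)NC1=O)c1ccc(-c2ccc3cccc(F)c3c2)[nH]c1=O` has not been measured yet. Its difference from compound 3 is this: 2,4-dioxo-1,3-oxazolidin-5-yl in place of 2,4-dioxo-1,3-thiazolidin-5-yl on a saturated chain carbon, two bonds along the chain from an aromatic carbon. In words, 2,4-dioxo-1,3-oxazolidin-5-yl replaces 2,4-dioxo-1,3-thiazolidin-5-yl on a saturated chain carbon, two bonds along the chain from an aromatic carbon.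

The closest guide is the same swap run the other way, a 6.6-fold lower number from compound 1 to compound 3 (0.82 log units; beyond the scatter). The larger 13-fold lower number from compound 2 to compound 3 (1.13 log units; beyond the scatter) also changes the chain, so it bears less directly, and a 2.0-fold higher number from compound 1 to compound 2 (0.31 log units; beyond the scatter) involves no swap of ring. For the measured compounds named here, compound 4 also has the opposite arrangement at the ring's stereocentre, which no measured pair isolates, so the range stays wide. A rise of similar size to the first step, beyond the scatter, is expected in this assay, namely a 5.6-fold higher number from compound 3 to compound 4 (0.75 log units; beyond the scatter). For compound 4 the estimated half-life is 0.8 h, with an expected range of 0.3 h to 2.2 h.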

Compound 4, half-life: 0.503 h
Beside the measured number, compound 4's estimate is 1.6-fold (0.20 log units) above it; low and high end bracket the measured number.
By their numbers in this assay, from the lowest: compound 3; then compounds 4 and 1 (each within the scatter of the next); then compound 2.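

In this assay, the oxygen ring again goes with a longer half-life than the sulfur ring (a 3.5-fold higher number from compound 3 to compound 4 (0.55 log units; beyond the scatter)), so the gain seen with compound 1 also appears with the other drawn configuration at the ring carbon. That configuration can now be judged on its own, and its step stays within the scatter (a 1.9-fold lower number from compound 1 to compound 4 (0.28 log units; within the scatter)), which rests on this: the fact that compounds 1 and 4 differ only in the configuration as drawn. Changing the directly attached 2,4-dioxo-1,3-oxazolidin-5-yl to (2,4-dioxo-1,3-oxazolidin-5-yl)methyl shortens the half-life beyond the scatter for this configuration as well (a 3.8-fold lower number from compound 2 to compound 4 (0.58 log units; beyond the scatter)).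

Which part of these compounds is broken down remains unknown. From the compounds shown here alone, it is also open whether a carboxylic acid or a 2,4-dioxoimidazolidin-5-yl group in place of the ring would keep this half-life.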